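This account rests on a few compounds, and the source may have more. Where it says the series, first, only, none or still open, it means among the compounds named here.

Of the compounds shown here, three with a shared core have been measured in a functional assay on YAC-1 cells (Mus musculus); a lower number here means a smaller maximal response, a higher number a larger maximal response. Compound 1 `Nc1nc(O)c2c(n1)n(C1OC(CO)[C@@H](O)[C@H]1O)c(=O)n2Cc1ccc(Cl)c(Cl)c1` carries a 3,4-dichlorobenzyl group on a ring nitrogen of that core. In this assay compound 1 gives 15%, the second highest of the three numbers. Compound 2 `CCCn1c(=O)n(C2CCC(COC(C)=O)O2)c2nc(NC(C)=O)nc(O)c21` lies nearest to it: in this assay compound 2 gives 0%, a number lower than that of compound 1 by more than the usual scatter. Compound 3 `C=CCn1c(=O)n([C@@H]2O[C@H](CO)[C@H]3OC(CCC)(CCC)O[C@H]32)c2nc(N)nc(O)c21` lies furthest away: in this assay compound 3 gives 56%, well beyond the scatter above compound 1.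

Compound 4 `N#Cc1ccc(Cn2c(=O)n(C3OC(CO)[C@@H](O)[C@H]3O)c3nc(N)nc(O)c32)cc1` has not yet been measured. It differs from compound 1 in one place: 4-cyanophenyl in place of 3,4-dichlorophenyl on a saturated chain carbon bound to an aromatic nitrogen

Among the compounds with values here, no pair of measured compounds differs by exactly such a change, so there is no measured step to lean on. A modest step from the value of compound 1 is expected, a number 5 percentage points higher from compound 1 to compound 4 (within the scatter), with the direction uncertain and a change within the scatter quite possible. For compound 4 a value of 20% is estimated, between 5% and 45%.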

Compound 4, largest response reached (reported as maximal response), in percent of the reference or control that the assay uses: 0%
Estimate against measurement, compound 4: 20 percentage points above; the whole stated range lies above it.
By their numbers in this assay, from the lowest: compounds 2 and 4 (each within the scatter of the next); then compound 1; then compound 3.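

At this place, on a saturated chain carbon bound to an aromatic nitrogen, the substituents on the phenyl ring matter in this assay: 4-cyanophenyl in place of 3,4-dichlorophenyl gives a number 15 percentage points lower from compound 1 to compound 4 (beyond the scatter). Within the data shown here, this is the first pair in the set that differs in one place only, so it is the first direct sign that the maximal response depends on this group while the rest of the molecule stays the same. No measurement available here explains the fall.

Both chlorine atoms leave and a nitrile enters in the same step, so this pair cannot show which of those changes counts. From the compounds shown here alone, a plain benzyl group, a benzyl group with a single chlorine, or a benzyl group carrying a carboxylic acid at this place would help to separate them, and how any of these behaves remains open.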